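Swapping the Ring on Sulfur in a Cytotoxic Imidazole Series

This account rests on a few compounds, and the source may have more. Where it says the series, first, only, none or still open, it means among the compounds named here.

Compound 3 `Cn1c(-c2ccc(NC(=O)CSc3nc4ccccc4s3)cc2)nc(-c2ccccc2)c1-c1ccccc1` gives 0.9% in a functional assay on MCF7 cells (Homo sapiens) for cytotoxicity, read by MTT assay, with a stated time of 24 h, tested at 0.64 ug/mL (a higher number here means a stronger effect of the compound at the concentration tested, a lower number a weaker effect), the lowest of the three numbers recorded, though its neighbours sit within the scatter: compound 2 `Cc1ccc2oc(SCC(=O)Nc3ccc(-c4nc(-c5ccccc5)c(-c5ccccc5)n4C)cc3)nc2c1` gives 1.1% and compound 1 `Cn1c(-c2ccc(NC(=O)CCl)cc2)nc(-c2ccccc2)c1-c1ccccc1` gives 3.4%. The two steps that replaced the chloro, a number 2.3 percentage points lower from compound 1 to compound 2 (within the scatter) and a number 2.5 percentage points lower from compound 1 to compound 3 (within the scatter), and the exchange of one ring on the sulfur, a number 0.2 percentage points lower from compound 2 to compound 3 (within the scatter), all stayed within the scatter. Compound 4 `Cn1cnnc1SCC(=O)Nc1ccc(-c2nc(-c3ccccc3)c(-c3ccccc3)n2C)cc1` carries 4-methyl-4H-1,2,4-triazol-3-yl in place of 1,3-benzothiazol-2-yl on a sulfur. Among the measured compounds shown here, the one measured step that bears on this change is the earlier ring exchange on the sulfur, which was flat, so no step beyond the scatter is expected in this assay. For compound 4 the expected value is 1.5%, within 0% to 9%, an expected step of a number 0.6 percentage points higher from compound 3 to compound 4 (within the scatter).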

Compound 4, a percentage reported as activity, at one concentration (the size of the read-out at that concentration, not a potency): 33.1%
Compound 4: the middle estimate sits 31.6 percentage points below what was measured; the measured number lies above the stated range.
By their numbers in this assay, from the lowest: compounds 3, 2 and 1 (each within the scatter of the next); then compound 4.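

In this assay, the ring on the sulfur proved able to move the number: 4-methyl-4H-1,2,4-triazol-3-yl gave a number 32.2 percentage points higher from compound 3 to compound 4 (beyond the scatter) and a number 32 percentage points higher from compound 2 to compound 4 (beyond the scatter), although the earlier exchange of 1,3-benzothiazol-2-yl and 5-methyl-1,3-benzoxazol-2-yl had stayed flat. The sulfanyl link alone does not account for the rise, since compounds 2 and 3 also carry it and stay within the scatter of compound 1, whereas the triazole gave a number 29.7 percentage points higher from compound 1 to compound 4 (beyond the scatter). Nothing available here explains the rise. Going by these compounds, it remains open whether the ring methyl is needed, and whether a dimethylamino group in place of the sulfanyl group would hold the number.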